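Hepatocyte stability of a piperazine series: ester in place of sulfonamide

The source may report more compounds than this note shows. Statements on the series, on what has been measured and on what is new or still open speak of the compounds shown alone.

Measured compounds and their values in an ADME assay on cells (Hepatocyte, Homo sapiens) for metabolic stability, with a stated time of 30 min; on this read-out lower numbers stand for a less stable compound and higher numbers for a more stable compound:
- compound 1, `CS(=O)(=O)NC1CCC(CN2CCN(c3cc(=O)c4cc(C(F)(F)F)cc([N+](=O)[O-])c4s3)CC2)CC1`: 105%
- compound 2, `O=c1cc(N2CCN(CC3CCC(NS(=O)(=O)c4ccccc4)CC3)CC2)sc2c([N+](=O)[O-])cc(C(F)(F)F)cc12`: 90.8%
- compound 3, `O=C(OC1CCC(CN2CCN(c3cc(=O)c4cc(C(F)(F)F)cc([N+](=O)[O-])c4s3)CC2)CC1)c1ccco1`: 1%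

Compound 2 stands second highest of the three numbers in this assay. Its nearest neighbour is compound 1, with a number 14.2 percentage points lower from compound 1 to compound 2 (beyond the scatter), the change being phenyl in place of methyl on a sulfonyl sulfur. The far neighbour is compound 3, with a number 89.8 percentage points lower from compound 2 to compound 3 (beyond the scatter).

Compound 4, `COc1ccc(C(=O)OC2CCC(CN3CCN(c4cc(=O)c5cc(C(F)(F)F)cc([N+](=O)[O-])c5s4)CC3)CC2)cc1`, is not yet measured. Relative to compound 2 the change is ((4-methoxyphenyl)carbonyl)oxy in place of (phenylsulfonyl)amino on a saturated ring carbon.

Within the data shown here, the step that bears most directly on this is the one from compound 2 to compound 3, in which ((furan-2-yl)carbonyl)oxy replaced (phenylsulfonyl)amino on the same saturated ring carbon: a number 89.8 percentage points lower from compound 2 to compound 3 (beyond the scatter). The parallel step from compound 1 supports it: a number 104 percentage points lower from compound 1 to compound 3 (beyond the scatter). Both steps, each swapping a sulfonamide-bearing group for a carbonyloxy-bearing group at this carbon, were large and downward. Compound 4 carries the same type of swap, with a (4-methoxyphenyl)carbonyl rather than a furan-2-yl carbonyl.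

A large downward step is therefore expected in this assay for compound 4, estimated as a number 85.8 percentage points lower from compound 2 to compound 4 (beyond the scatter). The value for compound 4 is expected near 5%, within a range of 0% to 25%.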

Compound 4, percent of the compound remaining: 12.2%
For compound 4 the middle estimate is 7.2 percentage points below the measured one; the measured number falls inside the stated range.
By their numbers in this assay, from the lowest: compound 3; then compound 4; then compound 2; then compound 1.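

In this assay the low number at this saturated ring carbon is not confined to one carbonyloxy group: the second such group, ((4-methoxyphenyl)carbonyl)oxy, also gives large drops, with a number 78.6 percentage points lower from compound 2 to compound 4 (beyond the scatter) and with a number 92.8 percentage points lower from compound 1 to compound 4 (beyond the scatter) in the step from the methanesulfonamido compound. The group on the carbonyl carbon also shifts the number, as 4-methoxyphenyl in place of furan-2-yl gives a number 11.2 percentage points higher from compound 3 to compound 4 (beyond the scatter) as a modest step, small beside the swap of the whole group. Across these four compounds the two sulfonamides stand high and the two esters low, and none goes against that split.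

No measurement at hand bears on why the numbers fall with these groups.

On these data alone, it stays open whether the low numbers go with the ester link itself or with the loss of the sulfonamide. An amide carrying the same (4-methoxyphenyl)carbonyl on this ring carbon would speak to that, as would a simple hydroxyl or a primary amine there, and no aryl group beyond 4-methoxyphenyl and furan-2-yl appears on the carbonyl carbon.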